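Aminopyridinyl for carbamoyl in a shared-core ether series

A few compounds are considered here, and "the series" means these few. Any claim that something is new, unique, unknown or untested is made for them only; others in the source may bear on it.

The series is followed in an ADME assay on Caco-2 cells (Homo sapiens) for permeability, in the apical to basolateral direction; on this read-out higher numbers stand for higher permeability and lower numbers for lower permeability. Compound 1 `NC(=O)c1cccc(Oc2ccc3c(c2)c(=O)ncn3Cc2c(F)cc(F)cc2F)c1C(F)(F)F` gives 1.9 10^-6 cm/s and stands highest of the two numbers in hand. Within the data shown here, compound 2 `O=C(Nc1ccccn1)c1cccc(Oc2ccc3c(c2)c(=O)ncn3Cc2c(F)cc(F)cc2F)c1C(F)(F)F` gives 1.2 10^-6 cm/s, and the single measured step, a 1.6-fold lower number from compound 1 to compound 2 (0.20 log units; within the scatter), lies within the scatter, so the two compounds are not told apart. Compound 3 `O=c1ncn(Cc2c(F)cc(F)cc2F)c2ccc(Oc3cccc(-c4ccc5cc[nH]c5c4)c3C(F)(F)F)cc12` carries an indolyl group in the same position as the carbamoyl of compound 1, but in this assay compound 3 gives "not determined" (no result reported), so it adds nothing to the numbers.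

Compound 4 `Nc1ccc(-c2cccc(Oc3ccc4c(c3)c(=O)ncn4Cc3c(F)cc(F)cc3F)c2C(F)(F)F)cn1` is to be measured. It differs from compound 1 in one place: 6-aminopyridin-3-yl in place of carbamoyl on an aromatic carbon.

Among the measured compounds shown here, no measured step bears directly on this change. For the measured compounds named here, the only step in hand, the one from compound 1 to compound 2, concerns a group on the amide-type nitrogen and stayed within the scatter; the exchange in compound 4 removes that amide-type group altogether and sets a six-membered aromatic ring with one hetero atom in its place, ortho to a trifluoromethyl group and meta to a large group. Going by the values given here, with no step of that kind to lean on, the expectation for compound 4 in this assay is a number close to that of compound 1, that is a 1.3-fold higher number from compound 1 to compound 4 (0.12 log units; within the scatter), without a shift beyond the scatter. The estimate for compound 4 is therefore 2.5 10^-6 cm/s, in a range from 1 10^-6 cm/s to 6 10^-6 cm/s.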

Compound 4, apparent permeability: 4.1 10^-6 cm/s
Compound 4: the middle estimate sits 1.6-fold (0.21 log units) below what was measured, and the stated range covers the measured number.
By their numbers in this assay, from the lowest: compounds 2 and 1 (each within the scatter of the next); then compound 4.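

Among these compounds, on an aromatic carbon ortho to a trifluoromethyl group and meta to a large group, 6-aminopyridin-3-yl in place of carbamoyl gives a 2.2-fold higher number from compound 1 to compound 4 (0.33 log units; beyond the scatter) in this assay and is the first single change to pass beyond the scatter, whereas the earlier change on the amide-type nitrogen did not. Replacing the (pyridin-2-yl)carbamoyl group at the same carbon gives a 3.4-fold higher number from compound 2 to compound 4 (0.53 log units; beyond the scatter) on the same read-out, so the higher number of compound 4 holds against both amide-bearing compounds, although both steps remain modest and compound 1 and compound 2 are not told apart from each other. No measurement in hand accounts for this rise, so the notes record the size of the change and no cause.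

The compounds shown do not separate the aromatic ring from its amino group, and a plain pyridin-3-yl or phenyl group at this carbon would address that question. They also leave open whether a carboxylic acid, a nitrile or a methylamine at the same carbon would stay with the amides or with compound 4 on this read-out.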